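Methyl on the linker chain of a furoxan-quinone ester

The source may hold more compounds than are shown below. What is called first, only, known or untested is meant among the compounds shown, and "the series" means these compounds.

Compound 2 `CC1=C(CCC(=O)OCCCOc2no[n+]([O-])c2S(=O)(=O)c2ccccc2)C(=O)c2c(O)cccc2C1=O` is known in a functional assay on A549 cells (Homo sapiens) for inhibition, read by MTT assay, with a stated time of 72 h (a lower number here means a stronger inhibitor, a higher number a weaker inhibitor), only as a limit, giving > 20000 nM. Compound 1 `CC1=C(C(C)CC(=O)OCC(C)COc2no[n+]([O-])c2S(=O)(=O)c2ccccc2)C(=O)c2c(O)cccc2C1=O` gives 12800 nM in this assay. Going by the values given here, compound 3 `CC1=C(C(C)CC(=O)OCCCOc2no[n+]([O-])c2S(=O)(=O)c2ccccc2)C(=O)c2c(O)cccc2C1=O` differs from compound 2 by methyl in place of hydrogen on a saturated chain carbon bound to a double-bonded ring carbon and a saturated chain carbon; no step between measured compounds covers this change. Among the compounds with values here, the value of compound 1 in this assay, which carries the same methyl, offers the only guide. The step from compound 2 to compound 3 is expected to be modest and toward stronger inhibition, about an at least 1.3-fold lower number from compound 2 to compound 3 (0.12 log units; that floor lies within the scatter). Compound 3 is therefore expected to give about 15000 nM in this assay, within 6000 nM to 40000 nM.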

Compound 3, half-maximal inhibitory concentration: 13900 nM
Estimate against measurement, compound 3: 1.1-fold (0.03 log units) above; measured number inside the range.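

In this assay, methyl in place of hydrogen on a saturated chain carbon bound to a double-bonded ring carbon and a saturated chain carbon gives an at least 1.4-fold lower number from compound 2 to compound 3 (0.15 log units; that floor lies within the scatter). The true size of this step stays unfixed because compound 2 is known only as a limit: the limit of > 20000 nM in this assay, at which 1 of the 3 values shown sits.

Hydrogen in place of the second methyl, on a saturated chain carbon bound to two saturated chain carbons, gives a 1.1-fold higher number from compound 1 to compound 3 (0.04 log units; within the scatter), so that methyl makes no readable difference in this assay.

Open, going by these compounds, is whether an ethyl group or a hydroxyl group on the first of these chain carbons would shift the number beyond the scatter.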